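A Dimethylamino Group in Place of Ring Hydrogen

The compounds below may be only part of what the source reports. "The series", "measured", "known", "first", "only" and "open" are said of these compounds alone.

Compound 1 `CCOC(=O)C12C(=O)OCC=C1COC2c1ccccc1` stands at the weak end of the numbers shown. In a functional assay on A549 cells (Homo sapiens) for cytotoxicity, read by MTT assay (a higher number here means a weaker inhibitor, a lower number a stronger inhibitor), compound 1 gives > 1000000 nM, a limit of the assay rather than a number, as the limit of > 1000000 nM in this assay, at which 1 of the 2 values shown sits, records. Compound 2 `CCOC(=O)C12C(=O)OCC=C1COC2c1cc(OC)c(OC)c(OC)c1` carries methoxy groups on the same ring, and in this assay compound 2 gives 13300 nM. Compound 3 `CCOC(=O)C12C(=O)OCC=C1COC2c1ccc(N(C)C)cc1` differs from compound 1 by dimethylamino in place of hydrogen on an aromatic carbon, para to a large group. Among the compounds with values here, no measured step joins them. The step expected in this assay is a modest gain, an at least 3.3-fold lower number from compound 1 to compound 3 (0.52 log units; beyond the scatter). Compound 3 is therefore estimated at 300000 nM, within a range of 30000 nM to 2000000 nM.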

Compound 3, half-maximal inhibitory concentration: 89600 nM
For compound 3 the middle estimate is 3.3-fold (0.52 log units) above the measured one; the measured number falls inside the stated range.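

In this assay, this position on the aromatic ring proves responsive to one change, which the earlier pair could not show because those compounds differ in more than one place. Dimethylamino in place of hydrogen gives an at least 11-fold lower number from compound 1 to compound 3 (1.04 log units; beyond the scatter) and so shows that this single group can move the result beyond the scatter. Going by these compounds, the true size of the step stays unknown, as compound 1 stands at a limit of the assay: the limit of > 1000000 nM in this assay, at which 1 of the 3 values shown sits.

On these data alone, whether a primary amine or a single methoxy group at this position would do the same remains open. So does the result of a carboxylic acid there.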